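Nitro in place of amino on a cytotoxicity read-out

A few compounds are considered here, and "the series" means these few. Any claim that something is new, unique, unknown or untested is made for them only; others in the source may bear on it.

Measured compounds:
- Compound 1, `Cc1cccc(-c2cccc(NCc3cncn3Cc3ccccc3)c2)c1C`: > 1000 nM
- Compound 2, `COC(=O)c1ccc(NCc2cncn2Cc2ccc(N)cc2)cc1-c1ccccc1`: > 10000 nM
- Compound 3, `CC(C)c1cccc(NCc2cncn2Cc2ccccc2)c1`: > 1000 nM

All three were tested in a toxicity assay on NIH3T3 cells (Mus musculus) for cytotoxicity, read by resazurin assay; on this read-out higher numbers stand for an effect only at larger amounts of compound and lower numbers for an effect already at smaller amounts. For compound 1 the value > 1000 nM is a limit of the assay, not a number. For compound 3 the value > 1000 nM is likewise a limit. Within the data shown here, the only one-place step among them, a step that the two limits leave unreadable from compound 1 to compound 3, is therefore unreadable in size. Compound 2 stands apart: its value > 10000 nM is also a limit, and it sits at the limit of > 10000 nM in this assay, at which 1 of the 3 values shown sits, whereas the other two sit at the limit of > 1000 nM in this assay, at which 2 of the 3 values shown sit.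

Compound 4, `COC(=O)c1ccc(NCc2cncn2Cc2ccc([N+](=O)[O-])cc2)cc1-c1ccccc1`, differs from compound 2 only in that (nitro in place of amino on an aromatic carbon). Among the measured compounds shown here, no measured step touches this change, so the expectation rests on compound 2 alone, whose value > 10000 nM is a limit. Compound 4 is expected to show a step that the limit leaves unreadable from compound 2 to compound 4, that is, none beyond the scatter. Compound 4 is thus estimated at 15000 nM in this assay, in the range 5000 nM to 50000 nM, most likely again reported only as a limit.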

Compound 4, half-maximal effective concentration: > 10000 nM
Compound 4 ended at the assay's limit; the forecaster's own chance of this, stated with the estimate: 75%; the middle value does not contradict the limit.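

In this assay, compound 2 and compound 4 both end at a limit of the assay and not at a number, so no step can be read between them: the limit of > 10000 nM in this assay, at which 2 of the 4 values shown sit.

The compounds shown leave open at what amount, if any, compound 2 or compound 4 would harm these cells, and whether nitro in place of amino shifts that amount.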